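Bromoaryl vinyl sulfones: swapping the arylidene ring

This account rests on a few compounds, and the source may have more. Where it says the series, first, only, none or still open, it means among the compounds named here.

Measured so far:
compound 1 `O=C(/C(=C\c1csc([N+](=O)[O-])c1)S(=O)(=O)c1ccc(Br)cc1)c1ccc(Br)cc1` gives 1000 nM in a functional assay on DU-145 cells (Homo sapiens) for inhibition, read by trypan blue exclusion, with a stated time of 96 h; a lower number here means a stronger inhibitor of growth, a higher number a weaker inhibitor of growth.
compound 2 `O=C(/C(=C\c1c(O)cc(O)cc1O)Sc1ccccc1Br)c1ccc(Cl)cc1` gives > 100000 nM in this assay; this is a limit, not a number.

For the measured compounds named here, compound 1 carries the only real number in this assay. Going by the values given here, the other value is the limit of > 100000 nM in this assay, at which 1 of the 2 values shown sits, so no step between measured compounds can be drawn and nothing is known about how large a change in the arylidene ring moves growth inhibition here.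

Compound 3 `O=C(/C(=C\c1ccc(Br)c([N+](=O)[O-])c1)S(=O)(=O)c1ccc(Br)cc1)c1ccc(Br)cc1` is not yet measured. It differs from compound 1 by 4-bromo-3-nitrophenyl in place of 5-nitrothiophen-3-yl on a double-bonded chain carbon bound to a double-bonded chain carbon. Both rings keep a nitro group and both are aromatic, and the rest of the shared core is untouched, so the step is expected to stay near the scatter: a 1.5-fold higher number from compound 1 to compound 3 (0.18 log units; within the scatter) is the expected step, with neither direction favoured beyond that. For compound 3 the estimate in this assay is 1500 nM, with a range from 300 nM to 8000 nM.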

Compound 3, concentration for 50% growth inhibition: 10000 nM
For compound 3 the middle estimate is 6.7-fold (0.82 log units) below the measured one; measured number above the stated range.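

In this assay, the place on a double-bonded chain carbon bound to a double-bonded chain carbon now has its first readable step: 4-bromo-3-nitrophenyl in place of 5-nitrothiophen-3-yl gives a 10-fold higher number from compound 1 to compound 3 (1.00 log units; beyond the scatter). A nitro group on both rings therefore does not by itself preserve the growth inhibition of compound 1, and this ring change is not neutral. Steps to compound 2 cannot be read, and no measurement shown bears on why this step arises.

From the compounds shown here alone, the step combines a change of ring with the arrival of a bromo group, so which of the two carries it stays open, and a plain 3-nitrophenyl ring would separate them. Also open, going by these compounds, is how an amine or a carboxylic acid on this ring would read in this assay.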